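The source may report more compounds than this note shows. Statements on the series, on what has been measured and on what is new or still open speak of the compounds shown alone.

Measured compounds:
Compound 1, `COc1ccc(OC(=O)Nc2ccc([Se]C#N)cc2)cc1`, 19200 nM in an ADME assay on 184B5 cells (Homo sapiens) for cytotoxicity, read by MTT assay, with a stated time of 72 h; on this read-out higher numbers stand for weaker inhibition of growth and lower numbers for stronger inhibition of growth
Compound 2, `CC(C)COC(=O)Nc1ccc([Se][Se]c2ccc(NC(=O)OCC(C)C)cc2)cc1`, 10500 nM in this assay
Compound 3, `CCCOC(=O)Nc1ccc([Se]C#N)cc1`, 9100 nM in this assay

Compound 3 stands with the number of compound 2 within the usual scatter, while the number of compound 1 lies beyond it. Compound 4, `CCCCOC(=O)Nc1ccc([Se]C#N)cc1`, has not yet been measured in this assay. It differs from compound 3 by one change: methyl in place of hydrogen on a saturated chain carbon, three bonds along the chain from an oxygen next to a carbonyl group. For the measured compounds named here, no step between measured compounds of this kind is known here, so there is no measured guide for what a longer chain does. Compound 4 is expected to sit close to compound 3, with a step of a 1.1-fold lower number from compound 3 to compound 4 (0.06 log units; within the scatter) that stays within the scatter and has no clear direction. Compound 4 is estimated at 8000 nM in this assay, between 4000 nM and 18000 nM.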

Compound 4, concentration for total growth inhibition: 14500 nM
Compound 4: middle estimate off by 1.8-fold (0.26 log units), on the low side, and the stated range covers the measured number.
By their numbers in this assay, from the lowest: compounds 3, 2, 4 and 1 (each within the scatter of the next, the first and the last beyond it).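

In this assay, for the compounds shown here, the change from propyl to butyl gives a 1.6-fold higher number from compound 3 to compound 4 (0.20 log units; within the scatter) as the first measured step at this position. Methyl in place of hydrogen on this saturated chain carbon is therefore not shown to move the number in either direction, although the earlier compounds offered no such comparison. Nothing measured here explains the result. Going by these compounds, it remains open whether a longer chain, such as hexyl, would move the number beyond the scatter. A branched chain or a terminal amine at this position is equally untested in what is shown.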